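This account rests on a few compounds, and the source may have more. Where it says the series, first, only, none or still open, it means among the compounds named here.

Series notes. Compound 1 `NC[C@H]1C[C@H]1c1c[nH]cn1` and compound 2 `NC[C@@H]1C[C@@H]1c1c[nH]cn1` share all atoms and bonds and differ only in configuration as drawn, with both stereocentres inverted, mirror images of each other. In an assay on isolated protein for inhibition of histamine H2 receptor (Homo sapiens) (on this read-out higher numbers stand for an effect only at larger amounts of compound and lower numbers for an effect already at smaller amounts), compound 1 gives > 0.0001 nM, which is a limit of the assay and not a number. In this assay compound 2 likewise gives > 0.0001 nM, again a limit. The step that the two limits leave unreadable from compound 1 to compound 2 cannot be read because of the limit of > 0.0001 nM in this assay, at which 2 of the 2 values shown sit; the pair is tied only by the fact that compounds 1 and 2 differ only in the configuration as drawn. Compound 3 `NC[C@H]1C[C@@H]1c1c[nH]cn1` is the next member. From compound 2 to compound 3, (the two compounds have the same atoms and bonds and differ only in configuration as drawn: 1 of 2 stereo elements differ; a stereocentre at a saturated ring carbon is drawn R in compound 2 and S in compound 3). Among the compounds with values here, the single measured step is unreadable, so no measured step gives a usable size or direction for this change. Compound 3 is therefore expected to show a step that the limit leaves unreadable from compound 2 to compound 3 in this assay, with no direction that the data can support. Compound 3 is estimated at 0.0003 nM in this assay, in a range from 0.0001 nM to 0.01 nM, and a further limit rather than a number is the expected outcome.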

Compound 3, half-maximal effective concentration: > 0.0001 nM
Compound 3 gave a limit, no number (the forecaster's own chance of this, stated with the estimate: 85%); the middle value lies beyond the limit too.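

No new step can be read among compound 1, compound 2 and compound 3, because each gives a limit and not a number: the limit of > 0.0001 nM in this assay, at which 3 of the 3 values shown sit.
The compounds shown leave open whether configuration as drawn changes the effect in this assay at all, and in which direction and by how much.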